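This account rests on a few compounds, and the source may have more. Where it says the series, first, only, none or still open, it means among the compounds named here.

Working notes on the series. Compound 3 `N#Cc1cccc(COc2ccc(-c3cc(CN4CCN(Cc5ccc(C(F)(F)F)cc5)CC4)no3)cc2)c1` gives the lowest number of the three measured, at 100 nM in a functional assay on Huh-7 cells (Homo sapiens) for antiproliferative activity, read by sulforhodamine B assay, with a stated time of 72 h; on this read-out higher numbers stand for weaker inhibition and lower numbers for stronger inhibition; compound 1 `FC(F)(F)c1ccc(CN2CCN(Cc3cc(-c4ccc(OCc5ccccc5Cl)cc4)on3)CC2)cc1` gives 1000 nM, and compound 2 `FC(F)(F)c1ccc(CN2CCN(Cc3cc(-c4ccc(OCc5ccc(Cl)cc5)cc4)on3)CC2)cc1` gives 4000 nM. Compound 4 `Fc1ccc(COc2ccc(-c3cc(CN4CCN(Cc5ccc(C(F)(F)F)cc5)CC4)no3)cc2)cc1` differs from compound 3 by 4-fluorophenyl in place of 3-cyanophenyl on a saturated chain carbon bound to an oxygen on an aromatic ring. Among the compounds with values here, the steps that bear on this are a 10-fold lower number from compound 1 to compound 3 (1.00 log units; beyond the scatter) and a 40-fold lower number from compound 2 to compound 3 (1.60 log units; beyond the scatter), both moving away from a chlorophenyl toward the 3-cyanophenyl; the step of a 4.0-fold higher number from compound 1 to compound 2 (0.60 log units; beyond the scatter) separates the two chlorophenyls. Since compound 4 carries a halogen-bearing phenyl and not the nitrile-bearing one, the change is expected to undo part of the gain seen in compound 3, so a step of a 10-fold higher number from compound 3 to compound 4 (1.00 log units; beyond the scatter) toward a higher number is expected in this assay. Compound 4 is therefore estimated at 1000 nM, within 250 nM to 4000 nM.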

Compound 4, half-maximal inhibitory concentration: 2000 nM
Estimate against measurement, compound 4: 2.0-fold (0.30 log units) below, within the range that was stated.
By their numbers in this assay, from the lowest: compound 3; then compounds 1, 4 and 2 (each within the scatter of the next, the first and the last beyond it).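

In this assay, a 20-fold higher number from compound 3 to compound 4 (1.30 log units; beyond the scatter) shows that the gap to the 3-cyanophenyl at this place is not confined to chlorophenyls, as it also holds for 4-fluorophenyl. Compound 4 is not resolved from the chlorophenyl compounds, with a 2.0-fold lower number from compound 2 to compound 4 (0.30 log units; within the scatter) and a 2.0-fold higher number from compound 1 to compound 4 (0.30 log units; within the scatter). No available measurement accounts for the gap between the nitrile-bearing compound and the halogen-bearing compounds. The compounds shown leave open whether the nitrile itself is needed, and a carboxylic acid or a primary amide in its place would test this.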